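A few compounds are considered here, and "the series" means these few. Any claim that something is new, unique, unknown or untested is made for them only; others in the source may bear on it.

All three were measured in an assay on HEK293 cells for displacement of a labelled ligand from growth hormone secretagogue receptor type 1 (Homo sapiens), with a stated time of 60 min; on this read-out higher numbers stand for weaker inhibition and lower numbers for stronger inhibition:

compound 1 `COc1cccc(-n2cc3nc(-c4cccnc4C)n(C[C@H]4CCCN(CC5CCCCO5)C4)c(=O)c3n2)c1` gives 120 nM
compound 2 `COC[C@H](C)N1CCC[C@H](Cn2c(-c3cccnc3C)nc3cn(-c4cccc(OC)c4)nc3c2=O)C1` gives 1.7 nM
compound 3 `COc1cccc(-n2cc3nc(-c4cccnc4C)n(C[C@H]4CCCN(Cc5cnco5)C4)c(=O)c3n2)c1` gives 120 nM

Compound 3 stands level with compound 1 at the digits shown, the two together giving the highest numbers of the three, while compound 2 sits far apart from both: a 71-fold higher number from compound 2 to compound 3 (1.85 log units; beyond the scatter). The unmeasured compound 4 `COc1cccc(-n2cc3nc(-c4cccnc4C)n(C[C@H]4CCCN(CC5CCCCC5)C4)c(=O)c3n2)c1` is derived from compound 3 by a single change, (cyclohexyl in place of 1,3-oxazol-5-yl on a saturated chain carbon bound to an amine nitrogen in a ring).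

Within the data shown here, two measured steps bear on this. The one that matches most closely is no change at the digits printed from compound 1 to compound 3 (within the scatter), where a saturated six-membered ring bearing one oxygen was exchanged for the five-membered aromatic ring, at the same place, without moving the number. The other is a 71-fold lower number from compound 1 to compound 2 (1.85 log units; beyond the scatter), but that step changes the branching of the group on the amine nitrogen in a ring rather than the ring at the end of it, and so tells less about the present change. Since swapping the ring at this position left the number untouched from compound 1 to compound 3, compound 4 is expected to show no step beyond the scatter, no change at the digits printed from compound 3 to compound 4 (within the scatter). Compound 4 is therefore estimated at 120 nM, within a range from 40 nM to 360 nM.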

Compound 4, half-maximal inhibitory concentration: 200 nM
Estimate against measurement, compound 4: 1.7-fold (0.22 log units) below; measured number inside the range.
By their numbers in this assay, from the lowest: compound 2; then compounds 1, 3 and 4 (each within the scatter of the next).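

In this assay, cyclohexyl in place of 1,3-oxazol-5-yl gives a 1.7-fold higher number from compound 3 to compound 4 (0.22 log units; within the scatter) and cyclohexyl in place of oxan-2-yl gives a 1.7-fold higher number from compound 1 to compound 4 (0.22 log units; within the scatter) so on a saturated chain carbon bound to an amine nitrogen in a ring, a ring of carbon only now falls within the scatter of both rings that carry hetero atoms. Going from 2 hydrogen-bond acceptors in 1,3-oxazol-5-yl to 0 in cyclohexyl thus brings no step beyond the scatter here. The gap to the branched group also holds for this all-carbon ring, since cyclohexylmethyl in place of 1-(methoxymethyl)ethyl on an amine nitrogen in a ring gives a 120-fold higher number from compound 2 to compound 4 (2.07 log units; beyond the scatter) and compound 2 alone stands apart among the four.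

From the compounds shown here alone, it remains open whether the low number of compound 2 goes with the branching, with the methoxy oxygen or with the lack of a ring at the end of the group. An isopropyl group or an unbranched 2-methoxyethyl chain on the same nitrogen would help separate these, and no measurement shown accounts for the gap.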